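Replacing the 2-methoxy-5-(trifluoromethyl)phenyl group of compound 1

The compounds below may be only part of what the source reports. "The series", "measured", "known", "first", "only" and "open" are said of these compounds alone.

Compound 1 (`COc1ccc(C(F)(F)F)cc1Nc1ncc(C(F)(F)F)c(N2Cc3cccc(N(C)S(C)(=O)=O)c3C2)n1`) sits at the edge of what could be read in a functional assay on OVCAR-3 cells (Homo sapiens) for antiproliferative activity, read by spectrophotometry, with a stated time of 2 days; a lower number here means a stronger inhibitor of growth, a higher number a weaker inhibitor of growth. There compound 1 gives > 30000 nM, which is a limit of the assay and not a number. Compound 2 (`COc1cc(N2CCN(C(C)=O)CC2)ccc1Nc1ncc(C(F)(F)F)c(N2Cc3cccc(N(C)S(C)(=O)=O)c3C2)n1`), which carries the same core, gives a true number in this assay, at 1600 nM.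

Compound 3 (`COc1cc(Nc2ncc(C(F)(F)F)c(N3Cc4cccc(N(C)S(C)(=O)=O)c4C3)n2)cc(OC)c1`) keeps the core of compound 1 and changes one group: 3,5-dimethoxyphenyl in place of 2-methoxy-5-(trifluoromethyl)phenyl on a nitrogen on an aromatic ring. Among the measured compounds shown here, no measured step covers this change, so any forecast is loose. For the measured compounds named here, compound 2, at 1600 nM, shows only that this core can reach a measurable value when the group on that nitrogen is changed. A modest move towards stronger growth inhibition is expected in this assay, and compound 3 may still end up at the limit. The estimated size of this move is an at least 2.5-fold lower number from compound 1 to compound 3 (0.39 log units; beyond the scatter). For compound 3 the expected value is 12000 nM, with an estimated range from 4000 nM to 30000 nM.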

Compound 3, concentration for 50% growth inhibition: 630 nM
Compound 3: the middle estimate sits 19-fold (1.28 log units) above what was measured, outside the stated range (below it).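

In this assay, putting 3,5-dimethoxyphenyl in place of 2-methoxy-5-(trifluoromethyl)phenyl on a nitrogen on an aromatic ring gives an at least 47-fold lower number from compound 1 to compound 3 (1.67 log units; beyond the scatter), so this one position can carry the shared core from the edge of the assay well into its readable range. Compound 2 had already shown that the core could give a true number, and compound 3 shows that this needs no more than a plain phenyl ring with two methoxy groups. The step is only a bound, and its full size cannot be read because compound 1 stands at a limit: the limit of > 30000 nM in this assay, at which 1 of the 3 values shown sits.

The change removes the trifluoromethyl group and alters the methoxy groups in a single move, so these compounds do not tell which part of it carries the gain. Going by these compounds, it also remains open how far this position tolerates other groups, such as a phenyl ring with a single methoxy group, or one with an amine or a carboxylic acid in place of a methoxy group.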